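The compounds below may be only part of what the source reports. "The series", "measured", "known", "first", "only" and "open" are said of these compounds alone.

Working notes on the series in an assay on CHO cells for binding affinity to corticotropin-releasing factor receptor 1 (Homo sapiens); on this read-out lower numbers stand for stronger inhibition and higher numbers for weaker inhibition.

For the measured compounds named here, compound 2 `CCCN(CC1CC1)c1cc(C)nc2c(-c3cnc(N(C)C)cc3C)c(C)nn12` gives 2.6 nM and stands at the lowest of the three numbers measured so far. Its neighbour is compound 3 `CCCCN(CCCC)c1cc(C)nc2c(-c3cnc(N(C)C)cc3C)c(C)nn12` with 4.2 nM, and the step of a 1.6-fold higher number from compound 2 to compound 3 (0.21 log units; within the scatter) lies within the scatter, so the two cannot be ordered. Compound 1 `CCC(COC)Nc1cc(C)nc2c(-c3cnc(N(C)C)cc3C)c(C)nn12` gives 260 nM; the step of a 100-fold lower number from compound 1 to compound 2 (2.00 log units; beyond the scatter) and the step of a 62-fold lower number from compound 1 to compound 3 (1.79 log units; beyond the scatter) are both large and beyond the scatter.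

The next compound to consider is compound 4 `CCCN(Cc1ccccc1)c1cc(C)nc2c(-c3cnc(N(C)C)cc3C)c(C)nn12`. The change from compound 2 is phenyl in place of cyclopropyl on a saturated chain carbon bound to a nitrogen on an aromatic ring. Both measured steps that changed the amino group wholesale, a 100-fold lower number from compound 1 to compound 2 (2.00 log units; beyond the scatter) and a 62-fold lower number from compound 1 to compound 3 (1.79 log units; beyond the scatter), moved from a secondary amine carrying a methoxymethyl group to a tertiary amine with two plain carbon substituents; compound 4 keeps a tertiary amine with a propyl group and so sits on the same side as compound 2 and compound 3. Going by the values given here, the only step among such tertiary amines, a 1.6-fold higher number from compound 2 to compound 3 (0.21 log units; within the scatter), was within the scatter. Among the compounds with values here, no measured step swaps a cyclopropyl for a phenyl, so the size of this change is unknown.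

The expectation for compound 4 is therefore a step of a 1.5-fold higher number from compound 2 to compound 4 (0.19 log units; within the scatter), not beyond the scatter. The estimate for compound 4 is 4 nM, with a range from 1.5 nM to 12 nM.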

Compound 4, inhibition constant: 5.2 nM
The estimate for compound 4 lay 1.3-fold (0.11 log units) below the measured number; the range from low to high includes it.
By their numbers in this assay, from the lowest: compounds 2, 3 and 4 (each within the scatter of the next); then compound 1.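

In this assay, phenyl in place of cyclopropyl on a saturated chain carbon bound to a nitrogen on an aromatic ring gives the step of a 2.0-fold higher number from compound 2 to compound 4 (0.30 log units; within the scatter), so this change cannot be told apart from repeat-measurement noise and the two compounds cannot be ordered. The earlier compounds shown here carried only open chains or a three-membered non-aromatic ring on the tertiary amine, whereas this result shows that a six-membered aromatic ring of carbon only, with 6 heavy atoms in place of 3, can stand at this position without a step beyond the scatter. The data shown give no measured basis for explaining this result.

The compounds shown leave open whether the benzyl group keeps this standing once its phenyl ring carries a substituent such as a carboxylic acid, an amine or a methoxy group, or once a pyridine ring takes the place of the phenyl. Also open, on these data alone, is what a longer chain, such as phenethyl in place of benzyl, would do at this nitrogen, and whether the propyl group can be exchanged while the benzyl group stays in place.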